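The source may report more compounds than this note shows. Statements on the series, on what has been measured and on what is new or still open speak of the compounds shown alone.

Compound 1 `NC(=O)c1c(NC(=O)c2ccccc2Cl)sc2c1CCN(C(=S)Nc1ccccc1Br)C2` carries a (2-chlorophenyl)carbonyl on one side of the shared core and a (2-bromophenyl)amino on the other. In a functional assay on HeLa cells (Homo sapiens) for antiproliferative activity, with a stated time of 24 h (on this read-out lower numbers stand for stronger inhibition and higher numbers for weaker inhibition), compound 1 gives 24600 nM. Compound 2 `NC(=O)c1c(NC(=O)c2ccccc2Cl)sc2c1CCN(C(=S)Nc1ccccc1C(F)(F)F)C2` differs from it by trifluoromethyl in place of bromo on an aromatic carbon. In this assay compound 2 gives 26700 nM, so that a 1.1-fold higher number from compound 1 to compound 2 (0.04 log units; within the scatter). Compound 3 `NC(=O)c1c(NC(=O)c2ccccc2I)sc2c1CCN(C(=S)Nc1ccccc1Br)C2` differs from compound 1 by iodo in place of chloro on an aromatic carbon. For compound 3 this assay returns only a limit, > 50000 nM, rather than a number. That reading, (the limit of > 50000 nM in this assay, at which 1 of the 3 values shown sits), means the step of an at least 2.0-fold higher number from compound 1 to compound 3 (0.30 log units; that floor lies within the scatter) is known only as a floor. Compound 4 `NC(=O)c1c(NC(=O)c2ccccc2I)sc2c1CCN(C(=S)Nc1ccccc1C(F)(F)F)C2` has not yet been measured in this assay. It differs from compound 3 by trifluoromethyl in place of bromo on an aromatic carbon, the same change that carried compound 1 to compound 2, here made on a core that differs by iodo in place of chloro on an aromatic carbon. For compound 4 the expected step is a step that the limit leaves unreadable from compound 3 to compound 4, because a 1.1-fold higher number from compound 1 to compound 2 (0.04 log units; within the scatter) shows this same change leaving the read-out within the scatter. Compound 4 is therefore estimated at 55000 nM, with a range from 30000 nM to 120000 nM, and the likeliest outcome is once more only a limit.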

Compound 4, half-maximal inhibitory concentration: 49200 nM
For compound 4 the middle estimate is 1.1-fold (0.05 log units) above the measured one, within the range that was stated.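

In this assay, iodo in place of chloro gives a 1.8-fold higher number from compound 2 to compound 4 (0.27 log units; within the scatter), and this does not separate the change on the two cores, although it cannot show that the change carries over exactly: the same change on two cores in this assay, an at least 2.0-fold higher number (0.30 log units; that floor lies within the scatter) from compound 1 to compound 3 and a 1.8-fold higher number (0.27 log units; within the scatter) from compound 2 to compound 4; the limit leaves it open whether they differ. Compound 3 remains at a limit, > 50000 nM, rather than a number. Trifluoromethyl in place of bromo gives an at least 1.0-fold lower number from compound 3 to compound 4 (0.00 log units; that floor lies within the scatter), a step known only as a floor, so this change has a readable size on only one core, and its transfer to the second core is neither confirmed nor ruled out: the same change on two cores in this assay, a 1.1-fold higher number (0.04 log units; within the scatter) from compound 1 to compound 2 and an at least 1.0-fold lower number (0.00 log units; that floor lies within the scatter) from compound 3 to compound 4; the limit leaves it open whether they differ.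

The compounds shown leave open what an amine, a methoxy group or a carboxylic acid in place of the bromo or the iodo would do to the read-out in this assay. They also leave open whether any such replacement would give a step beyond the usual scatter of this read-out.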